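The source may report more compounds than this note shows. Statements on the series, on what has been measured and on what is new or still open speak of the compounds shown alone.

Measured so far:
- compound 1 `Cc1nc(Nc2cccc(Cl)c2)sc1C(=O)/C=C/c1ccccc1`: in a functional assay on NCI-H460 cells (Homo sapiens) for cytotoxicity, read by MTT assay (on this read-out lower numbers stand for stronger inhibition and higher numbers for weaker inhibition), compound 1 gives > 25000 nM, which is a limit of the assay and not a number.
- compound 2 `Cc1nc(Nc2ccc(Cl)c(Cl)c2)sc1C(=O)/C=C/c1ccccc1`: in this assay compound 2 gives 22700 nM.
- compound 3 `Cc1ccccc1Nc1nc(C)c(C(=O)/C=C/c2ccccc2)s1`: in this assay compound 3 gives > 25000 nM, again a limit of the assay.

Compound 3 therefore stands at the edge of what this assay can report: of the three values, (the limit of > 25000 nM in this assay, at which 2 of the 3 values shown sit). From compound 2 the step reads an at least 1.1-fold higher number from compound 2 to compound 3 (0.04 log units; that floor lies within the scatter), and the step that the two limits leave unreadable from compound 1 to compound 3 cannot be read at all, since both ends are limits.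

The next compound, compound 4 `Cc1nc(Nc2ccccc2)sc1C(=O)/C=C/c1ccccc1`, differs from compound 3 in one place: hydrogen in place of methyl on an aromatic carbon. For the measured compounds named here, the only step in this set that can be read is an at least 1.1-fold lower number from compound 1 to compound 2 (0.04 log units; that floor lies within the scatter), which concerns a chloro group on a different ring and stays within the scatter. Going by the values given here, nothing among the measured steps points to a change beyond the scatter for the loss of the methyl group, and nothing points to a strong compound here.

The step from compound 3 to compound 4 is expected to be a step that the limit leaves unreadable from compound 3 to compound 4. Compound 4 is estimated at 30000 nM, in a range from 15000 nM to 80000 nM, with a real chance that the assay again reports only a limit.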

Compound 4, half-maximal inhibitory concentration: > 25000 nM
Compound 4: a limit, no number (the forecaster's own chance of this, stated with the estimate: 70%); the middle value lies beyond the limit too.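

Taking the methyl group off the ring of compound 3 does not bring a readable number into this assay: compound 4 gives > 25000 nM and this is a limit of the assay, not a number. The steps to compound 4 from compound 3 and from compound 1 cannot be read, since both ends are limits, so no size can be given to the loss of the methyl group or of the chloro group. For the compounds shown here, the one step that can be read is an at least 1.1-fold higher number from compound 2 to compound 4 (0.04 log units; that floor lies within the scatter) and it does not separate the unsubstituted phenyl from the 3,4-dichlorophenyl, so the new result only adds one more compound to those at the edge of the range: the limit of > 25000 nM in this assay, at which 3 of the 4 values shown sit.

The compounds shown leave open whether any group on this ring can give a value well inside the range of the assay. A methoxy group or an amine on this ring, or a carboxylic acid on the other phenyl ring, would test this, and only a compound that gives a real number would allow the size of such a change to be read.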